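The compounds below may be only part of what the source reports. "The series", "measured", "known", "first", "only" and "open" are said of these compounds alone.

Measured compounds:
Compound 1 `Cc1cc(-c2ccc(Cl)cc2)cc(=O)o1`: in a functional assay on A2780 cells (Homo sapiens) for inhibition (on this read-out lower numbers stand for stronger inhibition and higher numbers for weaker inhibition), compound 1 gives > 50000 nM, a limit of the assay.
Compound 2 `CCc1cc(C)oc(=O)c1`: in this assay compound 2 gives > 50000 nM, also a limit.
Compound 3 `Cc1cc(/C=C/c2ccccc2)cc(=O)o1`: in this assay compound 3 gives > 50000 nM, again a limit.

Compound 1 thus stands at no measured number at all; only a limit is known for it, and the two other compounds of the set give the same kind of result. Within the data shown here, no step between two measured compounds can be drawn, and all three values sit together at one boundary of the assay, as summarised by the limit of > 50000 nM in this assay, at which 3 of the 3 values shown sit.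

Compound 4 `Cc1cc(-c2ccc(C=O)cc2)cc(=O)o1` has not been measured. It differs from compound 1 by formyl in place of chloro on an aromatic carbon, in words: formyl in place of chloro on an aromatic carbon. Among the measured compounds shown here, since compound 1 and both of its companions stay at the limit, there is no measured step from which a direction or size could be read. The expected step from compound 1 to compound 4, a step that the limit leaves unreadable from compound 1 to compound 4, is therefore none beyond the scatter, and most likely a limit again. Compound 4 is estimated at 60000 nM, with a range from 12000 nM to 300000 nM.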

Compound 4, half-maximal inhibitory concentration: 19200 nM
The estimate for compound 4 lay 3.1-fold (0.49 log units) above the measured number; the measured number falls inside the stated range.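

In this assay, formyl in place of chloro on the aromatic carbon gives an at least 2.6-fold lower number from compound 1 to compound 4 (0.41 log units; beyond the scatter), which makes this position, on the six-membered aromatic ring of carbon only, the first place in the set where a change brings a measurable inhibition into view. Until now, neither the substituent on this ring nor the other compounds had given anything but a boundary value, and compound 4 alone now stands off that boundary: the limit of > 50000 nM in this assay, at which 3 of the 4 values shown sit.
On these data alone, compound 1 gives > 50000 nM, which is a limit of the assay, so the step is a floor and its true size stays unknown.

The compounds shown do not tell whether the carbonyl of the formyl group carries this gain, or whether a hydroxymethyl group, a carboxylic acid, an amine or a nitrile on the same carbon would give a lower or a higher number. No other step among the compounds shown can be read, so it also stays open whether the same exchange would count for anything on a different part of the molecule.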